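Amino for Chloro: One Small Step Tried on Two Cores

The source may report more compounds than this note shows. Statements on the series, on what has been measured and on what is new or still open speak of the compounds shown alone.

Compound 3 `ClCc1ccc(Cn2cnc3c(Cl)nc(Cl)nc32)cc1` and compound 1 `Nc1nc(Cl)c2ncn(Cc3ccc(CCl)cc3)c2n1` share a core and differ in one place: amino in place of chloro on an aromatic carbon. In a functional assay on SW-620 cells (Homo sapiens) for cytotoxicity, read by sulforhodamine B assay, with a stated time of 48 h (a higher number here means that more compound is tolerated, a lower number that less compound is tolerated), compound 3 gives 56200 nM, and compound 1 gives 87100 nM, so the step runs a 1.5-fold higher number from compound 3 to compound 1 (0.19 log units; within the scatter). Compound 2 `ClCc1cccc(Cn2cnc3c(Cl)nc(Cl)nc32)c1` is built from the same atoms as compound 3, joined differently; the difference between the two cores is not broken down here. In this assay compound 2 gives 7760 nM, the lowest of the three numbers. Compound 4 `Nc1nc(Cl)c2ncn(Cc3cccc(CCl)c3)c2n1` carries the same change on the core of compound 2: amino in place of chloro on an aromatic carbon. A step of about a 1.4-fold higher number from compound 2 to compound 4 (0.15 log units; within the scatter) is expected, because compound 3 to compound 1 moved only a 1.5-fold higher number from compound 3 to compound 1 (0.19 log units; within the scatter). Compound 4 is therefore estimated at 11000 nM, most likely between 5000 nM and 25000 nM.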

Compound 4, concentration lethal to 50% of the cells: 57500 nM
Estimate against measurement, compound 4: 5.2-fold (0.72 log units) below, outside the stated range (above it).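

In this assay, amino in place of chloro on an aromatic carbon gives a 7.4-fold higher number from compound 2 to compound 4 (0.87 log units; beyond the scatter). Set beside the earlier step, the same change does not carry over from one core to the other at the same size: the same change on two cores in this assay, a 1.5-fold higher number (0.19 log units; within the scatter) from compound 3 to compound 1 and a 7.4-fold higher number (0.87 log units; beyond the scatter) from compound 2 to compound 4, 4.8-fold (0.68 log units) apart, beyond the scatter of two such steps

So in this series, the step measured on one core was a poor guide to the step on the other, but two pairs give no rule for other cores and do not explain why the steps differ.

Going by these compounds, only chloro and amino appear at this place, so the outcome with a methylamino or methoxy group there remains open. Also open, on these data alone, is whether the two cores would part in the same way with those groups.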